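This account rests on a few compounds, and the source may have more. Where it says the series, first, only, none or still open, it means among the compounds named here.

Compound 1 `COc1ccccc1C#Cc1nc2c(s1)C(=O)NCC2` is recorded in an assay on HEK293 cells for positive allosteric modulation of metabotropic glutamate receptor 5 (Homo sapiens), read by FLIPR, with a stated time of 1 h (on this read-out lower numbers stand for an effect already at smaller amounts and higher numbers for an effect only at larger amounts of compound), with the value > 10000 nM, which is a limit of the assay.
Compound 2 `Fc1cccc(C#Cc2nc3c(s2)CN(C2CCC2)CC3)c1` gives > 10000 nM, likewise a limit.
Compound 3 `CC1CC1C(=O)N1CCc2nc(C#Cc3ccccc3)sc2C1` gives 9.4 nM.

Among the measured compounds shown here, compound 3 thus stands as the only real number among the three; the other two sit at the limit of > 10000 nM in this assay, at which 2 of the 3 values shown sit. For the measured compounds named here, no pair of measured compounds differs in a single place, so no measured step is available. Compound 4 `O=C(C1CCCCC1)N1CCc2nc(C#Cc3ccccc3)sc2C1` carries the change (cyclohexyl in place of 2-methylcyclopropyl on a carbonyl carbon). A step of this kind, within the scatter or modestly beyond it toward weaker effect, is expected from compound 3 to compound 4 as a 2.7-fold higher number from compound 3 to compound 4 (0.42 log units; beyond the scatter). Compound 4 is therefore estimated at 25 nM, with a range from 8 nM to 80 nM.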

Compound 4, half-maximal effective concentration: 167 nM
Beside the measured number, compound 4's estimate is 6.7-fold (0.82 log units) below it; measured number outside the range, above it.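

Swapping the group on this carbonyl carbon matters in this assay: cyclohexyl in place of 2-methylcyclopropyl gives an 18-fold higher number from compound 3 to compound 4 (1.25 log units; beyond the scatter). Among the compounds shown here, this is the first measured step at this place, and compound 4 still gives a real number rather than a limit, so the six-membered ring weakens the effect without abolishing it. Nothing shown here accounts for the size of this step. Open, going by these compounds, is how a cyclopentyl, a phenyl or an open chain such as isopropyl would read on this carbonyl carbon, and so whether the step follows ring size at all.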